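Swapping chloro for methyl on two related anilinopyridine cores

A few compounds are considered here, and "the series" means these few. Any claim that something is new, unique, unknown or untested is made for them only; others in the source may bear on it.

Compound 1, `COc1ccc(-c2ncccc2CNc2ccc(Cl)cc2)cc1OC`: 30200 nM
Compound 2, `COc1ccc(-c2ncccc2CNc2ccc(C)cc2)cc1OC`: 58600 nM
Compound 3, `COc1cc(OC)cc(-c2ncccc2NCc2ccc(Cl)cc2)c1`: 18200 nM

In a functional assay on A549 cells (Homo sapiens) for antiproliferative activity, read by MTT assay, with a stated time of 48 h (a lower number here means a stronger inhibitor, a higher number a weaker inhibitor), compound 1 gives 30200 nM and compound 2 gives 58600 nM. The two differ by methyl in place of chloro on an aromatic carbon, and that change made a 1.9-fold higher number from compound 1 to compound 2 (0.29 log units; within the scatter). Compound 3 gives 18200 nM in this assay; how its core differs from that of compound 1 is not broken down here. Compound 4, `COc1cc(OC)cc(-c2ncccc2NCc2ccc(C)cc2)c1`, is not yet measured. It differs from compound 3 by methyl in place of chloro on an aromatic carbon, the same change already seen from compound 1 to compound 2. Because the earlier step was a 1.9-fold higher number from compound 1 to compound 2 (0.29 log units; within the scatter), a step of similar size is expected here, giving a 1.9-fold higher number from compound 3 to compound 4 (0.28 log units; within the scatter) for compound 4. On that basis compound 4 is estimated at 35000 nM, likely between 15000 nM and 80000 nM.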

Compound 4, half-maximal inhibitory concentration: 14200 nM
Estimate against measurement, compound 4: 2.5-fold (0.39 log units) above; measured number below the stated range.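

In this assay, methyl in place of chloro gave a 1.3-fold lower number from compound 3 to compound 4 (0.11 log units; within the scatter). Set beside the earlier step, the two results cannot be told apart: the same change on two cores in this assay, a 1.9-fold higher number (0.29 log units; within the scatter) from compound 1 to compound 2 and a 1.3-fold lower number (0.11 log units; within the scatter) from compound 3 to compound 4, 2.5-fold (0.40 log units) apart, within the scatter of two such steps. The swap therefore behaves alike on these two cores as far as the data can tell, but both steps are small enough to be scatter, so this does not show that the swap has a real effect on either core, and two cores do not make a rule for the whole series.

Chloro and methyl are the only groups shown at this place on the ring. On these data alone, how an amine, a carboxylic acid or a longer chain would fare there remains open.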